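This account rests on a few compounds, and the source may have more. Where it says the series, first, only, none or still open, it means among the compounds named here.

Measured so far:
Compound 1, `COc1ccc(C(F)(F)F)cc1NC(=O)CN1CCN(S(=O)(=O)N2CCC(C)CC2)CC1`, in an assay on HEK293 cells for inhibition of potassium channel subfamily T member 1 (Homo sapiens), read by thallium flux (a lower number here means a stronger inhibitor, a higher number a weaker inhibitor), compound 1 gives 2400 nM.
Compound 2, `COc1ccc(Cl)cc1NC(=O)[C@@H](C)N1CCN(S(=O)(=O)N2CCC(C(F)(F)F)CC2)CC1`, in this assay compound 2 gives 3500 nM.
Compound 3, `COc1ccc(Cl)cc1NC(=O)CN1CCN(S(=O)(=O)N2CCC(C)CC2)C[C@@H]1C`, in this assay compound 3 gives 3500 nM.

Compound 2 stands level with compound 3 at the digits shown, the two together giving the highest numbers of the three; compound 1 gives a somewhat lower number, but the gap lies within the scatter, so no order among the three can be claimed.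

Compound 4, `COc1ccc(Cl)cc1NC(=O)[C@@H](C)N1CCN(S(=O)(=O)N2CCC(C)CC2)CC1`, has not yet been measured. It differs from compound 2 in one place: methyl in place of trifluoromethyl on a saturated ring carbon. Among the measured compounds shown here, no measured pair shows this change on its own, so nothing in the data gives its size. For this assay, the expected step from compound 2 to compound 4 is small, none beyond the scatter, in either direction: a 1.2-fold lower number from compound 2 to compound 4 (0.07 log units; within the scatter). Compound 4 is therefore estimated at 3000 nM, within the range 1200 nM to 7500 nM.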

Compound 4, half-maximal inhibitory concentration: 4900 nM
The estimate for compound 4 lay 1.6-fold (0.21 log units) below the measured number, within the range that was stated.
By their numbers in this assay, from the lowest: compounds 1, 2, 3 and 4 (each within the scatter of the next, the first and the last beyond it).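

Among the compounds shown here, compound 2 and compound 4 give the first direct reading of methyl in place of trifluoromethyl on this saturated ring carbon: this assay shows a 1.4-fold higher number from compound 2 to compound 4 (0.15 log units; within the scatter) for the change. On this one pair, the two groups cannot be told apart at this position. Nothing measured here bears on the reason for this result. The compounds shown leave open how a hydroxyl group, an amine or a longer chain would read at this position, and whether the same swap would read alike on the core of compound 3.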